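Fluoro for trifluoromethoxy: working notes on the series

The compounds below may be only part of what the source reports. "The series", "measured", "known", "first", "only" and "open" are said of these compounds alone.

In a functional assay on the whole organism for inhibition, with Lemna aequinoctialis as the target, with a stated time of 7 days, tested at 500 ug/mL (on this read-out higher numbers stand for more inhibition of growth at the one concentration tested and lower numbers for less inhibition of growth), compound 1 (`O=C1Nc2ccc(F)cc2/C1=N/NC(=S)Nc1cccc(C(F)(F)F)c1`) gives 30% and compound 2 (`O=C1Nc2ccc(F)cc2/C1=N/NC(=S)Nc1ccc(OC(F)(F)F)cc1`) gives 35%. Compound 2 thus stands level with compound 1, the two values lying within the scatter of each other. Compound 3 (`O=C1Nc2ccc(F)cc2/C1=N/NC(=S)Nc1ccc(F)cc1`) has fluoro in place of trifluoromethoxy on an aromatic carbon. Among the compounds with values here, no measured pair shows this change, so no step beyond the scatter is expected in this assay. The expected change is a number 5 percentage points lower from compound 2 to compound 3 (within the scatter). Compound 3 is estimated at 30%, with an expected range of 15% to 45%.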

Compound 3, percent growth inhibition at one concentration: 35%
Compound 3: the middle estimate sits 5 percentage points below what was measured; the measured number falls inside the stated range.
By their numbers in this assay, from the lowest: compounds 1, 2 and 3 (each within the scatter of the next).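

In this assay, within the data shown here, the first readable step at this position is no change at the digits printed from compound 2 to compound 3 (within the scatter), with fluoro in place of trifluoromethoxy on an aromatic carbon, para to a large group. Trifluoromethoxy has 5 heavy atoms and fluoro has 1, yet the read-out does not separate the two groups at this position. No measurement offered here accounts for this result. Going by these compounds, it remains open whether a group of another kind at this position, such as an amine or a carboxylic acid, would move the read-out beyond the scatter relative to compound 2.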